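The source may hold more compounds than are shown below. What is called first, only, known or untested is meant among the compounds shown, and "the series" means these compounds.

The measured compounds:
compound 1, `CC(O)(CSc1ccc(F)cc1)C(=O)Nc1ccc(S(F)(F)(F)(F)F)cc1`, 12500 nM;
compound 2, `CC(O)(CSc1ccc(C(F)(F)F)cc1)C(=O)Nc1ccc(S(F)(F)(F)(F)F)cc1`, 17000 nM;
compound 3, `CC(O)(CS(=O)(=O)c1ccc(F)cc1)C(=O)Nc1ccc(S(F)(F)(F)(F)F)cc1`, 18200 nM.

All three were tested in a functional assay on LNCaP cells (Homo sapiens) for antiproliferative activity, read by propidium iodide staining, with a stated time of 96 h; on this read-out higher numbers stand for weaker inhibition and lower numbers for stronger inhibition. Compound 1 and compound 2 differ by trifluoromethyl in place of fluoro on an aromatic carbon, and this change gave a 1.4-fold higher number from compound 1 to compound 2 (0.13 log units; within the scatter). Compound 3 carries the same fluoro group as compound 1, but the difference between the two cores is not broken down here. Compound 4, `CC(O)(CS(=O)(=O)c1ccc(C(F)(F)F)cc1)C(=O)Nc1ccc(S(F)(F)(F)(F)F)cc1`, has not yet been measured; it stands to compound 3 as compound 2 stands to compound 1, through (trifluoromethyl in place of fluoro on an aromatic carbon), the same change at the same place. Because the earlier step was a 1.4-fold higher number from compound 1 to compound 2 (0.13 log units; within the scatter), the step from compound 3 to compound 4 in this assay is expected to be similar, a 1.4-fold higher number from compound 3 to compound 4 (0.14 log units; within the scatter). Compound 4 is therefore estimated at 25000 nM, expected to lie between 12000 nM and 50000 nM.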

Compound 4, half-maximal inhibitory concentration: 20700 nM
For compound 4 the middle estimate is 1.2-fold (0.08 log units) above the measured one, within the range that was stated.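

In this assay, trifluoromethyl in place of fluoro on the core of compound 3 gave a 1.1-fold higher number from compound 3 to compound 4 (0.06 log units; within the scatter). Set beside the earlier step on the core of compound 1, the change carried over to the second core without a difference that can be told apart: the same change on two cores in this assay, a 1.4-fold higher number (0.13 log units; within the scatter) from compound 1 to compound 2 and a 1.1-fold higher number (0.06 log units; within the scatter) from compound 3 to compound 4, 1.2-fold (0.08 log units) apart, within the scatter of two such steps. Both steps lie within the scatter, so the pair shows neither a real effect of this change nor how it would behave on any core beyond these two.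

The compounds shown leave open whether another group in place of the fluoro, such as an amine, a carboxylic acid or a nitrile, would give a step beyond the scatter. They also leave open what a longer chain in that place would do.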